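The compounds below may be only part of what the source reports. "The series", "measured", "known", "first", "only" and "open" are said of these compounds alone.

Measured in a physicochemical assay for lipophilicity, read by HPLC; a higher number here means a more lipophilic compound, a lower number a more polar compound:
- compound 1 `Cc1ccsc1C(=CCCN(C)C(CCN)C(=O)NCc1ccc(F)cc1)c1sccc1C` gives 6.45
- compound 2 `Cc1ccsc1C(=CCCN(C)C(CC(C)O)C(=O)NCc1ccccc1)c1sccc1C` gives 5.64; 6.22 (2 entries)

Compound 1 has just this one number, and a further entry for it carries no single number. Compound 3 `Cc1ccsc1C(=CCCN(C)C(CC(C)O)C(=O)NCc1ccc(F)cc1)c1sccc1C` is not yet measured and differs from compound 1 in one group: 1-hydroxyethyl in place of aminomethyl on a saturated chain carbon, two bonds along the chain from an amine nitrogen and a carbonyl carbon. In words, 1-hydroxyethyl sits in place of aminomethyl on a saturated chain carbon, two bonds along the chain from an amine nitrogen and a carbonyl carbon. For the measured compounds named here, no measured pair shows this change directly. The nearest guide is compound 2, which also carries 1-hydroxyethyl at that place and gives 5.64; 6.22 (2 entries), so a small downward shift is expected, hardly beyond the scatter of repeat measurements. The estimated size is a number 0.25 log units lower from compound 1 to compound 3 (within the scatter). For compound 3 the expected value is 6.2, with an estimated range from 5.7 to 6.7.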

Compound 3, partition coefficient: 5.51
Beside the measured number, compound 3's estimate is 0.69 log units above it, and the stated range ends above it.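

In this assay, placing 1-hydroxyethyl instead of aminomethyl on this saturated chain carbon gives a number 0.94 log units lower from compound 1 to compound 3 (beyond the scatter). For the compounds shown here, this is the first direct reading of the change, and it shows that the lipophilicity reading at this position responds to the swap, even though the entering group has 3 heavy atoms against 2 for the leaving one and the hydrogen-bond donor and acceptor counts stay the same. The size of the step still calls for some caution, as a compound with the same 1-hydroxyethyl group has entries that lie well apart: the several entries of compound 2 in this assay, 5.64; 6.22 (2 entries)

Going by these compounds, what remains open is how a carboxylic acid or a methoxy group at this place would read. It is also unclear whether a longer chain ending in an amine would move the number in the same direction.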